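Working notes on compounds 1 to 4

A few compounds are considered here, and "the series" means these few. Any claim that something is new, unique, unknown or untested is made for them only; others in the source may bear on it.

Measured so far:
compound 1, `Cc1cc(Nc2nc(Nc3ccc(C(=O)NC4CC(C)(C)N([O])C(C)(C)C4)cc3)ncc2[N+](=O)[O-])no1`: 7360 nM
compound 2, `Cc1cc(Nc2nc(Nc3ccc(C(=O)NC4CC(C)(C)N([O])C(C)(C)C4)cc3)ncc2[N+](=O)[O-])n[nH]1`: 37500 nM
compound 3, `Cc1cc(Nc2nc(Nc3ccc(C(=O)NC4CC(C)(C)N([O])C(C)(C)C4)cc3)ncc2F)no1`: 10800 nM

All numbers come from a functional assay on HepG2 cells (Homo sapiens) for antiproliferative activity, read by MTT assay, with a stated time of 48 h; a lower number here means a stronger inhibitor, a higher number a weaker inhibitor. Compound 1 carries a nitro group on its core; compound 3 is its counterpart, and the two cores differ by fluoro in place of nitro on an aromatic carbon. The step between them is a 1.5-fold higher number from compound 1 to compound 3 (0.17 log units; within the scatter), so the two values cannot be told apart. Compound 2 is made from compound 1 by 5-methyl-1H-pyrazol-3-yl in place of 5-methyl-1,2-oxazol-3-yl on a nitrogen on an aromatic ring, and that change costs potency: a 5.1-fold higher number from compound 1 to compound 2 (0.71 log units; beyond the scatter).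

Compound 4, `Cc1cc(Nc2nc(Nc3ccc(C(=O)NC4CC(C)(C)N([O])C(C)(C)C4)cc3)ncc2F)n[nH]1`, is not yet measured. It stands to compound 3 as compound 2 stands to compound 1: the change is 5-methyl-1H-pyrazol-3-yl in place of 5-methyl-1,2-oxazol-3-yl on a nitrogen on an aromatic ring. The surroundings of the place are the same in both cases, so this is the same change set on the fluoro core rather than on the nitro core. For the measured compounds named here, only one measured example of this change exists, so how far it carries over is open. Because compound 3 gives 10800 nM, close to compound 1, compound 4 is expected to show a step of a 5.1-fold higher number from compound 3 to compound 4 (0.71 log units; beyond the scatter) in this assay, about the size seen from compound 1 to compound 2. On that basis compound 4 is estimated at 55000 nM, with a likely range from 25000 nM to 120000 nM.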

Compound 4, half-maximal inhibitory concentration: 10800 nM
Beside the measured number, compound 4's estimate is 5.1-fold (0.71 log units) above it, outside the stated range (below it).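

Setting 5-methyl-1H-pyrazol-3-yl in place of 5-methyl-1,2-oxazol-3-yl on the fluoro core gives no change at the digits printed from compound 3 to compound 4 (within the scatter), so the cost seen on the nitro core does not carry over to this core: the same change on two cores in this assay, a 5.1-fold higher number (0.71 log units; beyond the scatter) from compound 1 to compound 2 and no change at the digits printed (within the scatter) from compound 3 to compound 4, 5.1-fold (0.71 log units) apart, beyond the scatter of two such steps

Read along the other edge of the same four compounds, fluoro in place of nitro with 5-methyl-1H-pyrazol-3-yl present gives a 3.5-fold lower number from compound 2 to compound 4 (0.54 log units; beyond the scatter), which differs from the step with 5-methyl-1,2-oxazol-3-yl present, so the two changes do not act independently here: the same change on two cores in this assay, a 1.5-fold higher number (0.17 log units; within the scatter) from compound 1 to compound 3 and a 3.5-fold lower number (0.54 log units; beyond the scatter) from compound 2 to compound 4, 5.1-fold (0.71 log units) apart, beyond the scatter of two such steps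

This shows that, within these four compounds, the size of the step depends on the core it is made on, but it rests on one pair per core and does not show why the steps differ or which of the two cores is the more typical case.

Open, on these data alone, is whether another group in place of nitro or fluoro, such as chloro or a nitrile, would behave like the nitro core or like the fluoro core when the same change is made. Also open, as far as these compounds go, is whether the dependence on the core holds for a different group on the same nitrogen, such as cyclopropyl.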